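The source may report more compounds than this note shows. Statements on the series, on what has been measured and on what is new or still open speak of the compounds shown alone.

Measured so far:
compound 1, `O=C1COc2ccc(-c3cccc(NS(=O)(=O)c4ccc(F)cc4)c3)cc2N1C1CC1`: > 40000 nM
compound 2, `O=C1COc2ccc(-c3cnc(Cl)c(NS(=O)(=O)c4ccc(F)cc4)c3)cc2N1c1ccc(F)cc1`: > 40000 nM

In a functional assay on HeLa cells (Homo sapiens) for antiproliferative activity, read by MTT assay, with a stated time of 72 h (a higher number here means a weaker inhibitor, a lower number a stronger inhibitor), compound 1 gives > 40000 nM, which is a limit of the assay and not a measured number. Compound 2 gives > 40000 nM in this assay, again a limit rather than a number. Going by the values given here, compound 1 thus stands at the limit of > 40000 nM in this assay, at which 2 of the 2 values shown sit, and compound 2 sits at the same limit, so no order between the two can be read and no measured step exists.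

Compound 3, `O=C1COc2ccc(-c3cccc(NS(=O)(=O)c4ccc(F)cc4)c3)cc2N1c1ccc(Cl)cc1`, is not yet measured. It differs from compound 1 by 4-chlorophenyl in place of cyclopropyl on an amide-type nitrogen in a ring. Compound 2 also sits at the limit with a different core, and nothing in the two values shown points to a direction for this change.

No step beyond the usual scatter is expected from compound 1 to compound 3; the expected step is a number no higher from compound 1 to compound 3 (the limit leaves the size open). Compound 3 is therefore expected to give about 40000 nM in this assay, within a range of 10000 nM to 120000 nM, most likely reported again only as a limit.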

Compound 3, half-maximal inhibitory concentration: 35000 nM
For compound 3 the middle estimate is 1.1-fold (0.06 log units) above the measured one; the range from low to high includes it.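

In this assay, going by these compounds alone, the amide-type nitrogen in a ring now has one substituent that gives a read number: with 4-chlorophenyl there, compound 3 gives 35000 nM, the first value that is not a limit. The change in place of cyclopropyl reads as an at least 1.1-fold lower number from compound 1 to compound 3 (0.05 log units; that floor lies within the scatter), so the data show only a floor for this step, and that floor does not establish a real difference at this position. For compound 1, > 40000 nM is a limit of the assay and not a number, which leaves the true size of the step unknown and shows only that 4-chlorophenyl is tolerated at this position without any clear gain.

Going by these compounds, whether an amine or a carboxylic acid on the phenyl ring, or a longer alkyl chain on the same nitrogen, would bring the number well away from this range remains open. The values shown still give little basis for ranking the series: the limit of > 40000 nM in this assay, at which 2 of the 3 values shown sit.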